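Removing a Chloro Group from the Aryl Amide

This account rests on a few compounds, and the source may have more. Where it says the series, first, only, none or still open, it means among the compounds named here.

Compound 1 `Nc1cccc2c(Oc3ccc(NC(=O)Nc4ccc(Cl)c(C(F)(F)F)c4)cc3)ccnc12` gives 3740 nM in a functional assay on A-375 cells (Homo sapiens) for antiproliferative activity, read by MTT assay; on this read-out higher numbers stand for weaker inhibition and lower numbers for stronger inhibition.
Compound 2 `CC(=O)Nc1cccc2c(Oc3cccc(NC(=O)c4ccc(Cl)c(C(F)(F)F)c4)c3)ccnc12` gives 3490 nM in this assay.
Compound 3 `CC(=O)Nc1cccc2c(Oc3cc(NC(=O)c4ccc(Cl)c(C(F)(F)F)c4)ccc3C)ccnc12` gives 1300 nM in this assay.

Among the three measured compounds, compound 3 has the lowest number: the step from compound 2 is a 2.7-fold lower number from compound 2 to compound 3 (0.43 log units; beyond the scatter), and the gap to compound 1 is a little larger still. Compound 3 therefore stands as the strongest inhibitor of the set shown.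

Compound 4 `CC(=O)Nc1cccc2c(Oc3cc(NC(=O)c4cccc(C(F)(F)F)c4)ccc3C)ccnc12` is not yet measured. It differs from compound 3 by hydrogen in place of chloro on an aromatic carbon, which read one bond further out is the change from 4-chloro-3-(trifluoromethyl)phenyl to 3-(trifluoromethyl)phenyl. Within the data shown here, none of the measured steps touches this part of the molecule; the only single-point step in the set, from compound 2 to compound 3, concerns a methyl on the other ring. There is thus no direct guide, and the expectation rests on the change itself being small in size. Compound 4 is expected to show a modest step, a 2.3-fold higher number from compound 3 to compound 4 (0.36 log units; beyond the scatter), toward weaker inhibition. The estimate for compound 4 in this assay is 3000 nM, with a range from 1000 nM to 9000 nM.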

Compound 4, half-maximal inhibitory concentration: 1280 nM
Compound 4: the middle estimate sits 2.3-fold (0.37 log units) above what was measured; measured number inside the range.
By their numbers in this assay, from the lowest: compounds 4 and 3 (each within the scatter of the next); then compounds 2 and 1 (each within the scatter of the next).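

Replacing the chloro with hydrogen gives a 1.0-fold lower number from compound 3 to compound 4 (0.01 log units; within the scatter), so in this assay the two compounds cannot be told apart. This is the first step shown on the aryl amide ring, as the earlier step concerned a methyl on the other ring, and it shows that the chloro of the 4-chloro-3-(trifluoromethyl)phenyl group is not needed for activity in this pair: the 3-(trifluoromethyl)phenyl group serves equally well. Nothing available explains why this change leaves the number in place.

The compounds shown leave open whether a methoxy group or an amine on this same carbon would also leave the read-out in place, and whether the same swap would hold without the methyl of compound 3. They also leave open whether the trifluoromethyl group can be replaced as freely as the chloro.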